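This account rests on a few compounds, and the source may have more. Where it says the series, first, only, none or still open, it means among the compounds named here.

Working notes on the shared core carrying an alkyl group on the aromatic nitrogen. Compound 1 `CCn1c(-c2ccc(OCc3c(-c4c(Cl)cccc4Cl)noc3C(C)C)cc2)nc2ccc(C(=O)O)cc21` gives 19.3 nM in an assay on isolated protein for agonist activity at Bile acid receptor (Homo sapiens), read by TR-FRET; on this read-out lower numbers stand for an effect already at smaller amounts and higher numbers for an effect only at larger amounts of compound. Compound 2 `CCCn1c(-c2ccc(OCc3c(-c4c(Cl)cccc4Cl)noc3C(C)C)cc2)nc2ccc(C(=O)O)cc21` gives 96.4 nM in this assay. Among the compounds with values here, the only step in hand is a 5.0-fold higher number from compound 1 to compound 2 (0.70 log units; beyond the scatter). Compound 2 therefore stands at the higher of the two numbers, with compound 1 the nearest neighbour at a clearly lower value.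

Compound 3 `CC(C)c1onc(-c2c(Cl)cccc2Cl)c1COc1ccc(-c2nc3ccc(C(=O)O)cc3n2CC2CC2)cc1` carries cyclopropyl in place of ethyl on a saturated chain carbon bound to an aromatic nitrogen. Within the data shown here, no measured pair repeats this exact change. Among the measured compounds shown here, the one step that bears on it, a 5.0-fold higher number from compound 1 to compound 2 (0.70 log units; beyond the scatter), shows that lengthening the chain at this place raised the number; nothing in hand tells whether closing the added carbons into a ring moves it back. The expectation for compound 3 is thus a number close to that of compound 2, with only a slight lean toward a lower value, a 1.2-fold lower number from compound 2 to compound 3 (0.08 log units; within the scatter). Compound 3 is estimated at 80 nM in this assay, within 25 nM to 300 nM.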

Compound 3, half-maximal effective concentration: 29.1 nM
Compound 3: the middle estimate sits 2.7-fold (0.44 log units) above what was measured; the range from low to high includes it.
By their numbers in this assay, from the lowest: compounds 1 and 3 (each within the scatter of the next); then compound 2.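

Going from propyl to cyclopropylmethyl on the aromatic nitrogen gives a 3.3-fold lower number from compound 2 to compound 3 (0.52 log units; beyond the scatter) and so shows that the number at this position does not simply rise as carbons are added beyond ethyl. Compared with the ethyl group of compound 1, the cyclopropylmethyl group gives a 1.5-fold higher number from compound 1 to compound 3 (0.18 log units; within the scatter) and the two cannot be told apart in this assay even though they differ in carbon count and in the presence of the three-membered ring. Among the three compounds, only the open propyl chain of compound 2 stands apart from the others.

On these data alone, whether a branched chain such as isobutyl, a larger ring such as cyclobutylmethyl or a longer chain such as butyl would stay with compound 1 and compound 3 or with compound 2 remains open. Nothing at hand explains why closing the ring brings the number back.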